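From nitro to amino: an expected step

The source may hold more compounds than are shown below. What is called first, only, known or untested is meant among the compounds shown, and "the series" means these compounds.

Compound 1 `FC(F)(F)c1nc2cc(Cl)c(Cl)cc2n1CC1CC1` gives 61300 nM
Compound 2 `O=[N+]([O-])c1ccccc1Cn1c(C(F)(F)F)nc2cc(Cl)c(Cl)cc21` gives 5900 nM

In a functional assay on HCT-116 cells (Homo sapiens) for cytotoxicity, read by MTT assay, with a stated time of 48 h (a higher number here means a weaker inhibitor of growth, a lower number a stronger inhibitor of growth), compound 2 holds the lower of the two numbers, and its gap to compound 1 lies beyond the scatter. Compound 3 `Nc1ccccc1Cn1c(C(F)(F)F)nc2cc(Cl)c(Cl)cc21` keeps the core of compound 2 but carries amino in place of nitro on an aromatic carbon, ortho to a large group (amino in place of nitro on an aromatic carbon). Among the compounds with values here, no measured pair shows this change, so the data offer no direct guide to its size. In this assay a modest rise is expected (a 2.0-fold higher number from compound 2 to compound 3 (0.31 log units; beyond the scatter)), at about the edge of the scatter. Compound 3 is estimated at 12000 nM (3500 nM to 40000 nM).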

Compound 3, concentration for 50% growth inhibition: 26100 nM
For compound 3 the middle estimate is 2.2-fold (0.34 log units) below the measured one; measured number inside the range.
By their numbers in this assay, from the lowest: compound 2; then compound 3; then compound 1.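

In this assay, amino in place of nitro on an aromatic carbon, ortho to a large group, now has a direct measure, and it costs growth inhibition: a 4.4-fold higher number from compound 2 to compound 3 (0.65 log units; beyond the scatter). Part of the advantage over cyclopropyl survives this change: a 2.3-fold lower number from compound 1 to compound 3 (0.37 log units; beyond the scatter). No measurement shown explains the size of either step. On these data alone, it remains open whether a nitrile, a methoxy group or a carboxylic acid at this place would stand nearer to nitro or to amino. As far as these compounds go, how a phenyl ring carrying no such group compares also remains open.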